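Cytotoxicity of three compounds and an untested methylamino analogue

The source may report more compounds than this note shows. Statements on the series, on what has been measured and on what is new or still open speak of the compounds shown alone.

Measured in an ADME assay on HepG2 2.2.15 cells (Homo sapiens) for cytotoxicity, read by MTT assay, with a stated time of 8 days; on this read-out lower numbers stand for higher toxicity in this test and higher numbers for lower toxicity in this test:
- Compound 1 `COCCNc1ccc(-c2nn(Cc3ccc(C#N)cc3)c(=O)c3ccccc23)c(F)n1`: > 100000 nM, a limit
- Compound 2 `CN(C)c1ccc(-c2nn(Cc3ccc(C#N)cc3)c(=O)c3ccccc23)c(F)n1`: 79200 nM
- Compound 3 `Cc1ccc(-c2nn(Cc3ccc(C#N)cc3)c(=O)c3ccccc23)c(F)n1`: > 100000 nM, a limit

Compound 3 has no exact number, only the limit > 100000 nM. Compound 1 stands at that same limit, so the series sits largely at the limit of > 100000 nM in this assay, at which 2 of the 3 values shown sit, and only compound 2 gives a number.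

Compound 4 `CNc1ccc(-c2nn(Cc3ccc(C#N)cc3)c(=O)c3ccccc23)c(F)n1` has not yet been measured. It differs from compound 3 by methylamino in place of methyl on an aromatic carbon, with methylamino in place of methyl on an aromatic carbon.

Among the measured compounds shown here, three measured steps bear on this change. Replacing dimethylamino with methyl gives an at least 1.2-fold higher number from compound 2 to compound 3 (0.10 log units; that floor lies within the scatter). Replacing (2-methoxyethyl)amino with methyl gives a step that the two limits leave unreadable from compound 1 to compound 3. Between the two amino groups lies an at least 1.2-fold lower number from compound 1 to compound 2 (0.10 log units; that floor lies within the scatter).

None of these steps is shown to exceed the scatter, so no step beyond the scatter is expected in this assay, and no firm direction can be given. Compound 4 may well be reported only as a limit. The expected change is an at least 1.1-fold lower number from compound 3 to compound 4 (0.04 log units; that floor lies within the scatter). Compound 4 is estimated at 90000 nM, with an expected range from 45000 nM to 150000 nM.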

Compound 4, half-maximal cytotoxic concentration: > 100000 nM
Compound 4: only a limit was reported; the forecaster's own chance of this, stated with the estimate: 60%; at least 1.1-fold (0.04 log units) between middle value and limit.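

In this assay, compound 4 carries a methylamino group on the aromatic carbon next to the ring nitrogen, where compound 3 carries methyl, and it joins the compounds that give no exact number: the limit of > 100000 nM in this assay, at which 3 of the 4 values shown sit.

The only readable new step is an at least 1.2-fold higher number from compound 2 to compound 4 (0.10 log units; that floor lies within the scatter), for hydrogen in place of methyl on the amino nitrogen, so the loss of that methyl is not shown to change the read-out by more than the usual scatter. The steps from compound 3 and from compound 1 to compound 4 cannot be read, as both ends of each are limits. Methyl and the two monosubstituted amino groups thus all end at the limit, and compound 2 alone gives a number.

As far as these compounds go, whether a cyclic amine such as morpholine or piperidine, or a carboxylic acid, at this position would bring the number down beyond the scatter stays open. Also open, from the compounds shown here alone, is how far compound 1, compound 3 and compound 4 lie from one another, since the limit hides any difference among them.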